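Chloro for fluoro on the outer anilide ring

The source may hold more compounds than are shown below. What is called first, only, known or untested is meant among the compounds shown, and "the series" means these compounds.

Measured so far in a functional assay on OVCAR-5 cells (Homo sapiens) for inhibition, read by CCK-8 assay, with a stated time of 72 h, tested at 10 uM; on this read-out higher numbers stand for more inhibition of growth at the one concentration tested and lower numbers for less inhibition of growth:
compound 1 `CN(C)C(=O)c1cc2cnc(Nc3ccc(NC(=O)C4(C(=O)Nc5ccc(F)cc5)CC4)cc3)nc2n1C1CCCC1`: 79.7%
compound 2 `CN(C)C(=O)c1cc2cnc(Nc3ccc(N)cn3)nc2n1C1CCCC1`: 68%
compound 3 `CN(C)C(=O)c1cc2cnc(Nc3ccc(NC(=O)C4(C(=O)Nc5cccc(F)c5)CC4)cc3)nc2n1C1CCCC1`: 85.6%

Compound 3 gives the highest of the three numbers in this assay, yet its gap to compound 1 is within the scatter, so the two cannot be told apart; only compound 2 sits beyond the scatter below it. For the measured compounds named here, the one measured step, a number 5.9 percentage points higher from compound 1 to compound 3 (within the scatter), is within the scatter.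

Compound 4 `CN(C)C(=O)c1cc2cnc(Nc3ccc(NC(=O)C4(C(=O)Nc5cccc(Cl)c5)CC4)cc3)nc2n1C1CCCC1` differs from compound 3 in one place: chloro in place of fluoro on an aromatic carbon. Going by the values given here, no measured step exchanges one halogen for another, so the only guide is that moving fluoro between positions on this ring changed little. The step is therefore expected to be small: a number 0.6 percentage points lower from compound 3 to compound 4 (within the scatter). Compound 4 is estimated at 85%, in the range 72% to 95%.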

Compound 4, percent growth inhibition at one concentration: 88.1%
For compound 4 the middle estimate is 3.1 percentage points below the measured one, and the stated range covers the measured number.
By their numbers in this assay, from the lowest: compound 2; then compounds 1, 3 and 4 (each within the scatter of the next).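

In this assay the exchange of one halogen for another on this ring reads a number 2.5 percentage points higher from compound 3 to compound 4 (within the scatter) and so 3-chlorophenyl and 3-fluorophenyl cannot be told apart here. Changing both the halogen and its position gives a number 8.4 percentage points higher from compound 1 to compound 4 (within the scatter) and so this wider change cannot be told apart from no change either. Nothing at hand offers a reason for this.

On these data alone, whether an amine or a methoxy group at this place would shift the number beyond the scatter remains open. So does whether compounds that look alike at one concentration would also look alike across a range of concentrations.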